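The compounds below may be only part of what the source reports. "The series", "measured", "known", "first", "only" and "open" are said of these compounds alone.

Working notes on the trimethoxyphenyl-triazole series. In a functional assay on HepG2 cells (Homo sapiens) for antiproliferative activity, read by MTT assay, with a stated time of 48 h (on this read-out higher numbers stand for weaker inhibition and lower numbers for stronger inhibition), compound 1 `COc1cc(-c2nnc(SCC(=O)c3ccc(Cl)cc3)n2N)cc(OC)c1OC` gives only a limit, > 100000 nM, as recorded in the limit of > 100000 nM in this assay, at which 1 of the 2 values shown sits. Within the data shown here, compound 2 `COc1cc(-c2nnc(SCC(=O)c3ccccc3F)n2N)cc(OC)c1OC` gives 22600 nM, the only actual number so far. Among the measured compounds shown here, the measured step of an at least 4.4-fold lower number from compound 1 to compound 2 (0.64 log units; beyond the scatter) is the sole comparison available, and it changes the aryl group, not the carbonyl's link. Compound 3 `COc1cc(-c2nnc(SCC(=O)Nc3ccccc3)n2N)cc(OC)c1OC` differs from compound 2 by anilino in place of 2-fluorophenyl on a carbonyl carbon. For the measured compounds named here, no measured step tests this kind of exchange, so the expected step of a 1.3-fold higher number from compound 2 to compound 3 (0.12 log units; within the scatter) is small with a wide band. Compound 3 is estimated at 30000 nM, between 8000 nM and 120000 nM.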

Compound 3, half-maximal inhibitory concentration: 49900 nM
Compound 3: middle estimate off by 1.7-fold (0.22 log units), on the low side; measured number inside the range.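

Among these compounds, the first exchange of an aryl group for anilino on this carbonyl carbon gives a 2.2-fold higher number from compound 2 to compound 3 (0.34 log units; beyond the scatter), so here 2-fluorophenyl keeps the lower number. The step from the 4-chlorophenyl analogue reads an at least 2.0-fold lower number from compound 1 to compound 3 (0.30 log units; that floor lies within the scatter), a floor too small to rank the two. Compound 1 remains a limit and not a number: the limit of > 100000 nM in this assay, at which 1 of the 3 values shown sits.

As far as these compounds go, how a benzylamino group or a carboxylic acid on this carbonyl carbon would read stays open. So does whether a fluorine on the anilino ring would lower the number.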